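Three Close Neighbours and a Chloro Substitution

A few compounds are considered here, and "the series" means these few. Any claim that something is new, unique, unknown or untested is made for them only; others in the source may bear on it.

All three measured compounds share one core, and all were tested in a functional assay on the whole organism (strain AKR) for inhibition, with Mus musculus as the target, read by paw edema, at a dose of 0.01 mmol/kg; on this read-out higher numbers stand for more inhibition at the one dose given (going by the name of the read-out) and lower numbers for less inhibition. Compound 1, `COc1cc(/C=C2/S/C(=N/c3nccs3)NC2=O)ccc1O`, gives 72.7%. Compound 2, `O=C1N/C(=N\c2nccs2)S/C1=C/c1ccc([N+](=O)[O-])cc1`, gives 66.1%. Compound 3, `O=C1N/C(=N\c2nccs2)S/C1=C/c1cccc([N+](=O)[O-])c1`, gives 69.4%. On these numbers compound 3 sits close to both of its neighbours: its gap to compound 1 and its gap to compound 2 are each within the usual scatter of repeated measurements, so none of the three can be told apart from the others with confidence.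

Compound 4, `O=C1N/C(=N\c2nccs2)S/C1=C/c1cccc(Cl)c1`, has not yet been measured. It differs from compound 3 in one place: chloro in place of nitro on an aromatic carbon. Among the measured compounds shown here, no pair of measured compounds shows the effect of such a swap, and the three measured compounds, which carry quite different groups on the same six-membered ring, all land at similar inhibition. That gives no reason to expect a large move in either direction; the step from compound 3 to compound 4 is estimated to stay within the scatter, a number 4.4 percentage points lower from compound 3 to compound 4 (within the scatter). For compound 4 the expected inhibition in this assay is therefore 65%, with a likely range from 50% to 78%.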

Compound 4, a percentage reported as inhibition, in the whole organism at one dose (the size of the read-out at that dose, not a potency): 44.5%
Compound 4: middle estimate off by 20.5 percentage points, on the high side; the measured number lies below the stated range.
By their numbers in this assay, from the lowest: compound 4; then compounds 2, 3 and 1 (each within the scatter of the next).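

In this assay, chloro in place of nitro on this aromatic carbon, meta to a large group, gives a number 24.9 percentage points lower from compound 3 to compound 4 (beyond the scatter), the only step shown so far that changes a single place in these compounds. The first three compounds, with different groups on the same six-membered ring, all lay within the scatter of one another, which could have suggested that the ring accepts many kinds of group, but this step shows that the choice of group on this carbon can matter a good deal at the one dose given. The change swaps nitro, with 3 heavy atoms and 2 hydrogen-bond acceptors, for chloro, with 1 heavy atom and no hydrogen-bond acceptors, yet no measurement here bears on which of these differences, if any, lies behind the drop.

A single swap leaves open whether nitro stands out at this carbon or chloro falls short there, and an amine or a nitrile on the same carbon would help to tell these apart. Also open, on these data alone, is whether chloro on another carbon of the ring would give a similar number.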